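This account rests on a few compounds, and the source may have more. Where it says the series, first, only, none or still open, it means among the compounds named here.

Compound 1 `O=C(CN1CCCCC1)Nc1ccc(-c2nc3cc(C(F)(F)F)ccc3[nH]2)cc1` gives 6000 nM in an ADME assay on MT4 cells (Homo sapiens) for cytotoxicity, read by MTT assay, with a stated time of 96 h; on this read-out higher numbers stand for lower toxicity in this test and lower numbers for higher toxicity in this test. Compound 2 `CCC(=O)Nc1ccc(-c2nc3cc(C(F)(F)F)ccc3[nH]2)cc1` reaches only the assay limit, >= 100000 nM. Compound 3 `CCN(CC)CC(=O)Nc1ccc(-c2nc3cc(C(F)(F)F)ccc3[nH]2)cc1` gives 8000 nM.

Compound 2 thus stands at the upper edge of what this assay reports, where only a limit is given (the limit of >= 100000 nM in this assay, at which 1 of the 3 values shown sits). Compound 4 `CCC(=O)Nc1ccc(-c2nc3cc(C(F)(F)F)ccc3n2C2CCCCC2)cc1` differs from compound 2 by cyclohexyl in place of hydrogen on an aromatic nitrogen. The measured steps, an at least 16-fold higher number from compound 1 to compound 2 (1.22 log units; beyond the scatter), a 1.3-fold higher number from compound 1 to compound 3 (0.12 log units; within the scatter) and an at least 12-fold lower number from compound 2 to compound 3 (1.09 log units; beyond the scatter), all concern the saturated chain carbon bound to the carbonyl carbon, not the aromatic nitrogen, so none of them bears on this change. With no guide, a step of an at least 2.0-fold lower number from compound 2 to compound 4 (0.30 log units; that floor lies within the scatter) is expected, and compound 4 is estimated at 50000 nM, between 10000 nM and 100000 nM.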

Compound 4, half-maximal cytotoxic concentration: 17000 nM
Beside the measured number, compound 4's estimate is 2.9-fold (0.47 log units) above it; low and high end bracket the measured number.
By their numbers in this assay, from the lowest: compounds 1 and 3 (each within the scatter of the next); then compound 4. At a limit, above all of these: compound 2.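

In this assay, the aromatic nitrogen of the five-membered ring proves to be a place where substitution changes the read-out: cyclohexyl in place of hydrogen gives an at least 5.8-fold lower number from compound 2 to compound 4 (0.76 log units; beyond the scatter). Going by these compounds alone, all earlier steps concerned the saturated chain carbon bound to the carbonyl carbon, so this is the first step seen at this nitrogen. Its size is only a floor because compound 2 stands at a limit: the limit of >= 100000 nM in this assay, at which 1 of the 4 values shown sits.

From the compounds shown here alone, whether methyl or a chain bearing an amine on this nitrogen would give a similar step remains open. So does the effect of cyclohexyl here when piperidin-1-yl or diethylamino sits on the chain, as in compound 1 and compound 3.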